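The source may report more compounds than this note shows. Statements on the series, on what has been measured and on what is new or still open speak of the compounds shown alone.

Of the compounds shown here, three sharing one core have been tested in a functional assay on RAW264.7 cells (Mus musculus) for inhibition; a higher number here means a weaker inhibitor, a lower number a stronger inhibitor. Compound 1 (`CCOC(=O)C1=CCCCC1S(=O)(=O)Nc1ccc(F)cc1F`) gives 16 nM, compound 2 (`COC(=O)C1=CCCCC1S(=O)(=O)Nc1ccc(F)cc1F`) gives 57 nM and compound 3 (`CCCCOC(=O)C1=CCCCC1S(=O)(=O)Nc1ccc(F)cc1F`) gives 140 nM. Compound 3 is therefore the weakest of the three, with both of its steps beyond the scatter: an 8.8-fold higher number from compound 1 to compound 3 (0.94 log units; beyond the scatter) and a 2.5-fold higher number from compound 2 to compound 3 (0.39 log units; beyond the scatter). The third step, a 3.6-fold higher number from compound 1 to compound 2 (0.55 log units; beyond the scatter), also raises the number, so both chain changes away from compound 1 weaken inhibition.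

Compound 4 (`CC(C)COC(=O)C1=CCCCC1S(=O)(=O)Nc1ccc(F)cc1F`) has the same atoms as compound 3, joined differently: isopropyl in place of propyl on a saturated chain carbon bound to an oxygen next to a carbonyl group. In words, this is isopropyl in place of propyl on a saturated chain carbon bound to an oxygen next to a carbonyl group, which also reads as butyl to isobutyl.

Among the measured compounds shown here, none of the measured steps introduces branching, so they bear on this change only indirectly. They do show that this assay responds modestly to changes at this place, and the largest is an 8.8-fold higher number from compound 1 to compound 3 (0.94 log units; beyond the scatter). A step smaller than that one is expected here, probably not beyond the scatter, with a slight lean towards a lower number since compound 3 already sits highest at 140 nM. The estimated step is a 1.4-fold lower number from compound 3 to compound 4 (0.15 log units; within the scatter). Compound 4 is expected to give about 100 nM, within an estimated range of 40 nM to 260 nM.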

Compound 4, half-maximal inhibitory concentration: 49 nM
The estimate for compound 4 lay 2.0-fold (0.31 log units) above the measured number, within the range that was stated.
By their numbers in this assay, from the lowest: compound 1; then compounds 4 and 2 (each within the scatter of the next); then compound 3.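

In this assay, the result shows that this place responds to the shape of the chain as well as to its length: with the same atoms joined differently, isopropyl in place of propyl gives a 2.9-fold lower number from compound 3 to compound 4 (0.46 log units; beyond the scatter) and so recovers part of what compound 3 loses. The recovery is only partial, since a 3.1-fold higher number from compound 1 to compound 4 (0.49 log units; beyond the scatter) still separates compound 4 from compound 1, which remains the strongest inhibitor of the four, while a 1.2-fold lower number from compound 2 to compound 4 (0.07 log units; within the scatter) places compound 4 level with compound 2 within the scatter. Nothing in the data shown explains why isobutoxycarbonyl differs from butoxycarbonyl at this place.

From the compounds shown here alone, with only ethyl, methyl, butyl and isobutyl esters at hand, it stays open whether a tert-butyl or cyclopropylmethyl ester, or a longer chain such as pentyl, would follow compound 4 or compound 3. Going by these compounds, it also stays open how the free carboxylic acid or a simple amide in place of the ester would behave on the same core.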